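This account rests on a few compounds, and the source may have more. Where it says the series, first, only, none or still open, it means among the compounds named here.

Measured compounds in a functional assay on HepG2 cells (Homo sapiens) for antiproliferative activity, read by XTT assay, with a stated time of 72 h; a higher number here means a weaker inhibitor, a lower number a stronger inhibitor:
compound 1, `CNc1ncnc2c1c(-c1ccsc1)cn2[C@@H]1O[C@H](CO)[C@@H](O)[C@H]1O`, gives only the assay limit > 20000 nM.
compound 2, `CSc1ncnc2c1c(-c1ccccc1)cn2[C@@H]1O[C@H](CO)[C@@H](O)[C@H]1O`, gives only the assay limit > 20000 nM.
compound 3, `CSc1ncnc2c1c(-c1cccs1)cn2[C@@H]1O[C@H](CO)[C@@H](O)[C@H]1O`, gives only the assay limit > 20000 nM.

Compound 3 stands at the assay limit in this assay, as do the other two values shown, so none of the three compounds can be placed against another. For the measured compounds named here, the one measured step that touches compound 3 is a step that the two limits leave unreadable from compound 2 to compound 3, and its size cannot be read because both ends of it are limits. The change from compound 3 to compound 4, `CSc1ncnc2c1c(-c1ccsc1)cn2[C@@H]1O[C@H](CO)[C@@H](O)[C@H]1O`, is thiophen-3-yl in place of thiophen-2-yl on an aromatic carbon. Going by the values given here, no measured step covers this particular exchange, and the only related observation is that compound 1, which carries the same thiophen-3-yl with a different group on the shared core, is also found at the limit, consistent with the limit of > 20000 nM in this assay, at which 3 of the 3 values shown sit. Accordingly the step expected for this exchange is a step that the limit leaves unreadable from compound 3 to compound 4, which is no resolvable movement beyond the scatter, and the most probable outcome is that compound 4 is again reported only as a limit. For compound 4 the estimated value in this assay is 40000 nM, with a range from 15000 nM to 300000 nM.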

Compound 4, half-maximal inhibitory concentration: > 15000 nM
Compound 4 ended at the assay's limit; the forecaster's own chance of this, stated with the estimate: 85%; the middle value does not contradict the limit.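

In this assay compound 4 gives > 15000 nM, a limit of the assay. The steps from compound 1, compound 2 and compound 3 to compound 4 cannot be read, as all four values are limits. The compounds shown leave open how thiophen-2-yl, thiophen-3-yl, phenyl, methylsulfanyl or methylamino on the shared core would rank, as none gives a value that is not a limit.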